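Acetoxy to hydroxy on an aromatic ring

The source may report more compounds than this note shows. Statements on the series, on what has been measured and on what is new or still open speak of the compounds shown alone.

In a functional assay on SGC-7901 cells (Homo sapiens) for inhibition (on this read-out higher numbers stand for weaker inhibition and lower numbers for stronger inhibition), compound 1 `COc1cc(OC)c2c(=O)cc(-c3ccccc3)oc2c1I` gives 2200 nM and compound 2 `CC(=O)Oc1c(I)c(O)c2c(=O)cc(-c3ccccc3)oc2c1I` gives 4200 nM as its result. These two numbers lie within the usual scatter of repeated measurements, so compound 2 stands level with compound 1 and neither can be called the better inhibitor. The next compound to be tested is compound 3 `O=c1cc(-c2ccccc2)oc2c(I)c(O)c(I)c(O)c12`, which is compound 2 with a single change hydrogen in place of acetyl on an oxygen on an aromatic ring that puts hydrogen in place of acetyl on an oxygen on an aromatic ring, or acetoxy to hydroxy in short. Going by the values given here, no measured pair of compounds shows this change on its own, so its size cannot be read directly from the data. Among the compounds with values here, the only guide is that compound 1 and compound 2 carry different groups on the shared core, and still compound 2 at 4200 nM lies within the scatter of compound 1. The step expected a 1.4-fold lower number from compound 2 to compound 3 (0.15 log units; within the scatter) is therefore a modest one that stays within the scatter, with no clear direction. For compound 3 the estimated value is 3000 nM with an expected range from 1000 nM to 9000 nM in this test.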

Compound 3, half-maximal inhibitory concentration: 2900 nM
Compound 3: middle estimate off by 1.0-fold (0.01 log units), on the high side; low and high end bracket the measured number.
By their numbers in this assay, from the lowest: compounds 1, 3 and 2 (each within the scatter of the next).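

In this assay, going by these compounds alone, the change from acetoxy to hydroxy can now be read directly for the first time: putting hydrogen in place of acetyl on an oxygen on an aromatic ring gives a 1.4-fold lower number from compound 2 to compound 3 (0.16 log units; within the scatter). This step lies within the scatter, so removing the acetyl, with its 3 heavy atoms and its double bond outside the aromatic rings, leaves no difference that this test can resolve, and neither compound 2 nor compound 3 can be called the better inhibitor. At this oxygen, then, the read-out does not separate a free hydroxy from an acetoxy group, although no measurement shown here offers any explanation for that.

Going by these compounds, what remains open is whether a larger change at this place would move the number beyond the scatter, for example a longer chain on the oxygen, such as a butanoyl ester, or an amine in place of the hydroxy. A single step also cannot show whether acetoxy to hydroxy would behave in the same way on a different core.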